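This account rests on a few compounds, and the source may have more. Where it says the series, first, only, none or still open, it means among the compounds named here.

Measured in a functional assay on HCT-116 cells (Homo sapiens) for antiproliferative activity, read by CellTiter-Glo, with a stated time of 10 days; a lower number here means a stronger inhibitor, a higher number a weaker inhibitor:
Compound 1 `COCc1cc(-c2cnn(C)c2-c2sc3ccccc3c2C#N)cc2c(CN)n[nH]c(=O)c12`: 19 nM
Compound 2 `Cn1ncc(-c2cc(C(F)F)c3c(=O)[nH]nc(CN)c3c2)c1-c1sc2ccccc2c1C#N`: 37 nM
Compound 3 `Cn1ncc(-c2cc(O)c3c(=O)[nH]nc(CN)c3c2)c1-c1sc2ccccc2c1C#N`: 188 nM

These three compounds share a core and differ only in one group on an aromatic carbon. Compound 2 has the second highest of the three numbers, but its nearest neighbour gives a 1.9-fold higher number from compound 1 to compound 2 (0.29 log units; within the scatter). Its furthest neighbour gives a 5.1-fold higher number from compound 2 to compound 3 (0.71 log units; beyond the scatter).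

The next compound to consider is compound 4 `Cc1cc(-c2cnn(C)c2-c2sc3ccccc3c2C#N)cc2c(CN)n[nH]c(=O)c12`, which has methyl in place of difluoromethyl on an aromatic carbon. Going by the values given here, no compound with methyl at this carbon has a measured value yet, so the expectation must lean on the other exchanges at the same spot. Swapping methoxymethyl for difluoromethyl made little difference, as a 1.9-fold higher number from compound 1 to compound 2 (0.29 log units; within the scatter) shows. Hydroxy is the exception, with a 9.9-fold higher number from compound 1 to compound 3 (1.00 log units; beyond the scatter).

Methyl is attached through carbon, as difluoromethyl and methoxymethyl are, whereas hydroxy is not. On that slender basis, compound 4 is expected to fall with the first two compounds rather than with compound 3 in this assay. The expected change is a 1.2-fold lower number from compound 2 to compound 4 (0.09 log units; within the scatter), so no step beyond the scatter is anticipated. Compound 4 is estimated at 30 nM, with an expected range from 12 nM to 80 nM.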

Compound 4, half-maximal inhibitory concentration: 30 nM
Compound 4: middle estimate and measured number agree at the digits printed; measured number inside the range.
By their numbers in this assay, from the lowest: compounds 1, 4 and 2 (each within the scatter of the next); then compound 3.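

In this assay, methyl at this aromatic carbon gives a 1.2-fold lower number from compound 2 to compound 4 (0.09 log units; within the scatter) and a 1.6-fold higher number from compound 1 to compound 4 (0.20 log units; within the scatter), so neither step separates it from the groups it replaces. Methyl has a single heavy atom and difluoromethyl has three, yet that difference in size leaves no mark here beyond the scatter, and taking the methoxy off methoxymethyl does not either. Hydroxy now stands apart from a third group, with a 6.3-fold lower number from compound 3 to compound 4 (0.80 log units; beyond the scatter), which leaves the three groups attached through carbon together and compound 3 as the only one outside them, although nothing measured on these compounds gives a reason for that gap.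

These four compounds cannot say whether the gap follows from the atom attached to the ring or from something particular to hydroxy, and an amine or a methoxy group placed directly on this carbon would bear on that question. As far as these compounds go, how far the tolerance for carbon-attached groups extends also stays open, since a longer chain or a carboxylic acid at the same spot could fall with either side.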